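A few compounds are considered here, and "the series" means these few. Any claim that something is new, unique, unknown or untested is made for them only; others in the source may bear on it.

Compound 3 (`CC(C)c1c(COc2cccc(OCC3CCOCC3)c2)[nH]c2ccccc2c1=O`) enters this account without a number. In an in vitro ADME assay on microsomes from liver (Mus musculus) for metabolic stability, tested at 0.2 uM (a lower number here means slower removal, a higher number faster removal of the compound), compound 3 stands at "not determined" (no result reported). Compound 2 (`Cc1ccc2[nH]c(COc3cccc(OCC4CCOCC4)c3)c(C)c(=O)c2c1`) is its close neighbour in the series, and compound 2 likewise stands at "not determined" (no result reported). Compound 1 (`CCCCOc1cccc(OCc2[nH]c3ccccc3c(=O)c2C)c1`) is the only one of the three with a reading. Compound 1 gives > 1000 mL/min/kg, which is a limit of the assay and not a number.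

The next compound, compound 4 (`Cc1c(COc2cccc(OCC3CCOCC3)c2)[nH]c2ccccc2c1=O`), differs from compound 3 in one place: methyl in place of isopropyl on an aromatic carbon. The changed group sits two atoms from the ring nitrogen. Compound 1 carries methyl at that same place, but the rest of its structure differs from compound 4.

Going by the values given here, with no measured step to lean on and no value for compound 3, the size of this change can only be judged loosely. A moderate step toward lower clearance is expected in this assay, though it cannot be checked against compound 3. The reading of compound 1 at > 1000 mL/min/kg warns that clearance in this series may run very high, so the expected range is kept wide. For compound 4 the estimated clearance is 400 mL/min/kg, with an expected range from 120 mL/min/kg to 1000 mL/min/kg.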

Compound 4, clearance: 420 mL/min/kg
For compound 4 the middle estimate is 1.1-fold (0.02 log units) below the measured one; low and high end bracket the measured number.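

Compound 4 gives the series its first reading in this assay that is a single number and not a limit, so a clearance can now be tied to methyl on this aromatic carbon, two atoms from the ring nitrogen. With methyl at this place on both sides of the comparison, the reading shows an at least 2.3-fold lower number from compound 1 to compound 4 (0.37 log units; beyond the scatter), with oxan-4-yl in place of propyl on a saturated chain carbon bound to an oxygen on an aromatic ring. That step gives only a lower bound on the size of the change and not the size itself, because compound 1 stands at a limit of the assay: the limit of > 1000 mL/min/kg in this assay, at which 1 of the 4 values shown sits.

Steps that involve compound 2 or compound 3 cannot be read, so the effect of methyl in place of isopropyl on clearance in this assay remains unknown. Also open, as far as these compounds go, is how clearance would respond to hydrogen, ethyl or cyclopropyl at this place, or to an amine in place of oxan-4-yl on the chain.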